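Shortening a polyamine tail on a chalcone scaffold

The source may report more compounds than this note shows. Statements on the series, on what has been measured and on what is new or still open speak of the compounds shown alone.

Measured so far:
- compound 1 `COc1ccc(/C=C/C(=O)c2cc(OC)c(OC)c(OC)c2)cc1OCCCC(=O)NCCCNCCCCNCCN`: 31800 nM
- compound 2 `COc1ccc(/C=C/C(=O)c2cc(OC)c(OC)c(OC)c2)cc1OCCCC(=O)NCCCCN(CCCN)CCCCN`: 60600 nM

In a functional assay on PC-3 cells (Homo sapiens) for antiproliferative activity, read by MTT assay, with a stated time of 48 h (on this read-out lower numbers stand for stronger inhibition and higher numbers for weaker inhibition), compound 2 gives the highest of the two numbers; its nearest neighbour is compound 1, and the gap between them, a 1.9-fold higher number from compound 1 to compound 2 (0.28 log units; within the scatter), lies within the scatter. Compound 3 `COc1ccc(/C=C/C(=O)c2cc(OC)c(OC)c(OC)c2)cc1OCCCC(=O)NCCCNCCCCN` is not yet measured in this assay. It differs from compound 2 in one place: (4-aminobutyl)amino in place of ((4-aminobutyl)(3-aminopropyl)amino)methyl on a saturated chain carbon, three bonds along the chain from an amide-type nitrogen. Among the measured compounds shown here, the only step available for comparison is the one from compound 1 to compound 2, which also reshaped this tail and changed the number by less than the scatter. On that basis, the step of a 1.3-fold lower number from compound 2 to compound 3 (0.13 log units; within the scatter) is expected to stay small, with no direction beyond the scatter, though a number nearer the range of compound 1 seems as likely as one near compound 2. Compound 3 is therefore estimated at 45000 nM, with a range of 15000 nM to 130000 nM in this assay.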

Compound 3, half-maximal inhibitory concentration: 81000 nM
For compound 3 the middle estimate is 1.8-fold (0.26 log units) below the measured one, within the range that was stated.
By their numbers in this assay, from the lowest: compounds 1, 2 and 3 (each within the scatter of the next, the first and the last beyond it).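

Among these compounds, only the loss of one piece of the tail moves the number beyond the scatter in this assay: hydrogen in place of 2-aminoethyl on an amine nitrogen gives a 2.5-fold higher number from compound 1 to compound 3 (0.41 log units; beyond the scatter) and so a modest loss of inhibition. The other change at this position, (4-aminobutyl)amino in place of ((4-aminobutyl)(3-aminopropyl)amino)methyl, gives a 1.3-fold higher number from compound 2 to compound 3 (0.13 log units; within the scatter) and cannot be told apart from no change, even though it removes more heavy atoms. No measurement is available that explains either step.

As far as these compounds go, it remains open whether a longer chain on that amine nitrogen would lower the number or leave it in the same range. From the compounds shown here alone, the effect of a carboxylic acid in place of the amine in this tail also remains open.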